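The source may report more compounds than this note shows. Statements on the series, on what has been measured and on what is new or still open speak of the compounds shown alone.

Measured in a functional assay on A549 cells (Homo sapiens) for antiproliferative activity, read by spectrophotometry, with a stated time of 2 days; a lower number here means a stronger inhibitor of growth, a higher number a weaker inhibitor of growth:
- compound 1 `Cc1ccc(Nc2ncc(C(F)(F)F)c(N3Cc4cccc(N(C)S(C)(=O)=O)c4C3)n2)c(Cl)c1`: > 30000 nM (a limit)
- compound 2 `COc1cc(Nc2ncc(C(F)(F)F)c(N3Cc4cccc(N(C)S(C)(=O)=O)c4C3)n2)cc(OC)c1`: 24800 nM
- compound 3 `COc1cc(Nc2ncc(C(F)(F)F)c(N3Cc4cccc(N(C)S(C)(=O)=O)c4C3)n2)cc(C(F)(F)F)c1`: > 30000 nM (a limit)

Compound 3 has no number, only the limit > 30000 nM. The series record shows (the limit of > 30000 nM in this assay, at which 2 of the 3 values shown sit).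

Compound 4 `CN(c1cccc2c1CN(c1nc(Nc3cc(Cl)cc(C(F)(F)F)c3)ncc1C(F)(F)F)C2)S(C)(=O)=O` has chloro in place of methoxy on an aromatic carbon. Going by the values given here, two measured steps bear on this, and both can be read only as floors: an at least 1.2-fold higher number from compound 2 to compound 3 (0.08 log units; that floor lies within the scatter), where methoxy also leaves, and an at least 1.2-fold lower number from compound 1 to compound 2 (0.08 log units; that floor lies within the scatter). Neither gives a reason to expect a change beyond the scatter. In this assay the expected step is a number no higher from compound 3 to compound 4 (the limit leaves the size open), so no size beyond the scatter is anticipated, and a further limit is the likeliest report. For compound 4 the estimate is 30000 nM, with an expected range of 12000 nM to 50000 nM.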

Compound 4, concentration for 50% growth inhibition: 6700 nM
Beside the measured number, compound 4's estimate is 4.5-fold (0.65 log units) above it; the whole stated range lies above it.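

In this assay, going by these compounds alone, chloro in place of methoxy, meta to a trifluoromethyl group, gives the first step beyond the scatter (an at least 4.4-fold lower number from compound 3 to compound 4 (0.65 log units; beyond the scatter)). The 3-chloro-5-(trifluoromethyl)phenyl group also separates compound 4 from the other two compounds (a 3.7-fold lower number from compound 2 to compound 4 (0.57 log units; beyond the scatter); an at least 4.4-fold lower number from compound 1 to compound 4 (0.65 log units; beyond the scatter)). A single-atom change at this position therefore moves the series off its limit.

As far as these compounds go, the full size of the steps from compound 1 and compound 3 remains open, as both compounds carry a limit: (the limit of > 30000 nM in this assay, at which 2 of the 4 values shown sit). From the compounds shown here alone, whether an amine or a nitrile at this position would match chloro also remains open.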